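Thiophen-3-yl for phenyl: expected inhibition of compound 4

A few compounds are considered here, and "the series" means these few. Any claim that something is new, unique, unknown or untested is made for them only; others in the source may bear on it.

Measured compounds:
compound 1 `Oc1ccccc1-c1cc(-c2ccccc2)cc(-c2ccccc2O)n1` — 0%
compound 2 `Oc1cccc(-c2cc(-c3ccccc3)cc(-c3ccccc3)n2)c1` — 12.9%
compound 3 `Oc1cccc(-c2cc(-c3ccccc3)cc(-c3cccs3)n2)c1` — 51.2%

In an assay on isolated protein for inhibition of DNA topoisomerase 1 (Homo sapiens), with a stated time of 30 min, tested at 100 uM (a higher number here means a stronger effect of the compound at the concentration tested, a lower number a weaker effect), compound 1 gives 0%, compound 2 gives 12.9% and compound 3 gives 51.2%. Compound 2 stands second highest of the three: compound 1 lies below it beyond the scatter, and the step of a number 38.3 percentage points higher from compound 2 to compound 3 (beyond the scatter) lies beyond the scatter in the other direction.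

Compound 4 `Oc1cccc(-c2cc(-c3ccccc3)cc(-c3ccsc3)n2)c1` differs from compound 2 in one place: thiophen-3-yl in place of phenyl on an aromatic carbon. Among the compounds with values here, the one measured step that bears on this change is a number 38.3 percentage points higher from compound 2 to compound 3 (beyond the scatter), where thiophen-2-yl replaced phenyl at the same aromatic carbon. Within the data shown here, a rise of comparable kind is therefore expected in this assay, though with no thiophen-3-yl analogue measured the size is uncertain. For compound 4 the estimate is 40%, between 15% and 65%, an expected step of a number 27.1 percentage points higher from compound 2 to compound 4 (beyond the scatter).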

Compound 4, a percentage reported as inhibition, at one concentration (the size of the read-out at that concentration, not a potency): 75.8%
Compound 4: middle estimate off by 35.8 percentage points, on the low side, and the stated range ends below it.
By their numbers in this assay, from the lowest: compound 1; then compound 2; then compound 3; then compound 4.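

The aromatic carbon next to the ring nitrogen accepts a second thiophene with a gain over phenyl: thiophen-3-yl in place of phenyl gives a large rise (a number 62.9 percentage points higher from compound 2 to compound 4 (beyond the scatter)). The point of attachment within the thiophene also counts, as thiophen-3-yl in place of thiophen-2-yl gives a further, modest rise (a number 24.6 percentage points higher from compound 3 to compound 4 (beyond the scatter)). No evidence at hand bears on the reason for either rise.

Open: whether furan-3-yl or pyridin-3-yl at this carbon keeps the gain, and whether an amine on the thiophen-3-yl ring adds to it.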